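The source may report more compounds than this note shows. Statements on the series, on what has been measured and on what is new or still open speak of the compounds shown alone.

Measured compounds:
compound 1 `CC(C)(C)OC(=O)N1C[C@@H](n2cc(-c3ccc4nc(N)sc4n3)nn2)C[C@H]1C(=O)Nc1ccc(Cl)cc1Cl` — 28.3%
compound 2 `Nc1nc2ccc(-c3cn([C@@H]4CN[C@H](C(=O)Nc5ccc(Cl)cc5Cl)C4)nn3)nc2s1` — 42.2%

In a functional assay on K562/Adr cells (Homo sapiens) for inhibition, read by MTT assay, with a stated time of 48 h, tested at 30 uM (on this read-out lower numbers stand for less inhibition and higher numbers for more inhibition at the one concentration tested (going by the name of the read-out)), compound 2 stands highest of the two measured compounds, above compound 1, which is its nearest neighbour, by a number 13.9 percentage points higher from compound 1 to compound 2 (beyond the scatter). Compound 3 `CC(=O)Nc1nc2ccc(-c3cn([C@@H]4CN[C@H](C(=O)Nc5ccc(Cl)cc5Cl)C4)nn3)nc2s1` differs from compound 2 by acetyl in place of hydrogen on a nitrogen on an aromatic ring. Going by the values given here, no measured step touches this nitrogen, so the one step known, from hydrogen in place of tert-butoxycarbonyl on the ring amine, does not bear on it. The author therefore expects no change beyond the scatter, a step of a number 2.2 percentage points lower from compound 2 to compound 3 (within the scatter). Compound 3 is estimated at 40%, within 20% to 60%.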

Compound 3, a percentage reported as inhibition, at one concentration (the size of the read-out at that concentration, not a potency): 36.1%
Estimate against measurement, compound 3: 3.9 percentage points above, within the range that was stated.
By their numbers in this assay, from the lowest: compounds 1, 3 and 2 (each within the scatter of the next, the first and the last beyond it).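

In this assay, going by these compounds alone, the change from amino to acetamido on the nitrogen on an aromatic ring gives a number 6.1 percentage points lower from compound 2 to compound 3 (within the scatter) and is the first step read at this position, as the earlier step touched only the ring amine nitrogen. At this position, acetyl in place of hydrogen therefore gives no step beyond the scatter. Nothing at hand explains this result. On these data alone, whether a methyl group, a longer chain such as propanoyl or a carboxylic acid on this nitrogen would read the same remains open.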